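The compounds below may be only part of what the source reports. "The series", "measured", "known", "first", "only" and "open" are said of these compounds alone.

Working notes on the series, which shares the core of compound 1 (`COc1cc(Oc2cccc(Nc3ccccc3)c2)cc(OC)c1CNCc1ccc(F)cc1`). In a functional assay on HCT-116 cells (Homo sapiens) for inhibition, read by MTT assay, with a stated time of 72 h (on this read-out higher numbers stand for weaker inhibition and lower numbers for stronger inhibition), compound 1 gives 4220 nM. Compound 2 (`COc1cc(Oc2cccc(Nc3ccccc3)c2)cc(OC)c1CNCc1ccc(Cl)cc1`) gives 3310 nM, which lies within the scatter of the compound 1 value, so the two cannot be ranked. The next structure is compound 3 (`COc1cc(Oc2cccc(Nc3ccccc3)c2)cc(OC)c1CNC(C)C`), which carries isopropyl in place of 4-chlorobenzyl on an amine nitrogen.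

Within the data shown here, only one measured step bears on this change: a 1.3-fold lower number from compound 1 to compound 2 (0.11 log units; within the scatter), with chloro in place of fluoro on an aromatic carbon. That step alters only the halogen on the ring, whereas compound 3 loses the whole 4-chlorobenzyl group. Among the measured compounds shown here, no measured compound lacks a halogenated benzyl group, so the data give no direct measure of this larger change. A modest move toward a higher number is expected in this assay, though with wide uncertainty, and a step lost in the scatter remains possible. The expected step is a 1.8-fold higher number from compound 2 to compound 3 (0.26 log units; within the scatter). For compound 3 the estimated value is 6000 nM, with an expected range of 2000 nM to 18000 nM.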

Compound 3, half-maximal inhibitory concentration: > 20000 nM
Compound 3: a limit, no number; the forecaster's own chance of this, stated with the estimate: 7%; at least 3.3-fold (0.52 log units) between middle value and limit.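

In this assay compound 3 stands as a limit and not as a number: the limit of > 20000 nM in this assay, at which 1 of the 3 values shown sits. The earlier exchange of halogen left the read-out within the scatter, whereas replacing the whole benzyl group on the amine nitrogen gives a change beyond it, seen as an at least 6.0-fold higher number from compound 2 to compound 3 (0.78 log units; beyond the scatter) and as an at least 4.7-fold higher number from compound 1 to compound 3 (0.67 log units; beyond the scatter). Among these compounds, this is the first sign that the group on this nitrogen matters in this assay, and since both steps rest on a limit, they give a lower bound on the size of the change and not the size itself.

The change from 4-chlorobenzyl to isopropyl removes the halogen and the aromatic ring and also shortens the group, so the compounds shown cannot say which of these carries the loss. An unsubstituted benzyl group would test the halogen, while a cyclohexylmethyl group or a longer alkyl chain on the same nitrogen would show whether the aromatic ring is needed or whether a group of similar size is enough.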